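A smaller ring on the amide nitrogen: compound 4

The compounds below may be only part of what the source reports. "The series", "measured", "known", "first", "only" and "open" are said of these compounds alone.

Compound 1 `CNC(=O)c1ccncc1Nc1cc(-c2ccc3ccn(C)c3c2)c2nccnc2c1`: 83 nM
Compound 2 `Cn1cc(CNC(=O)c2ccncc2Nc2cc(-c3ccc4ccn(C)c4c3)c3nccnc3c2)cn1`: 159 nM
Compound 3 `CN1CCC(NC(=O)c2ccncc2Nc2cc(-c3ccc4ccn(C)c4c3)c3nccnc3c2)CC1=O`: 41 nM

Of the compounds shown here, three sharing one core have been measured in an assay for inhibition of 6-phosphofructo-2-kinase/fructose-2,6-bisphosphatase 3 (Homo sapiens), read by ADP-Glo, with a stated time of 2 h; on this read-out higher numbers stand for weaker inhibition and lower numbers for stronger inhibition. Compound 1 carries a methyl on the amide nitrogen, and in this assay compound 1 gives 83 nM. Compound 2 carries a (1-methyl-1H-pyrazol-4-yl)methyl there and gives 159 nM; the step is a 1.9-fold higher number from compound 1 to compound 2 (0.28 log units; within the scatter). Compound 3 carries a 1-methyl-2-oxopiperidin-4-yl on that nitrogen and gives 41 nM, the lowest of the three numbers. The steps leading to it are a 2.0-fold lower number from compound 1 to compound 3 (0.31 log units; beyond the scatter) and a 3.9-fold lower number from compound 2 to compound 3 (0.59 log units; beyond the scatter).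

Compound 4 `CN1CC(NC(=O)c2ccncc2Nc2cc(-c3ccc4ccn(C)c4c3)c3nccnc3c2)C1` has not yet been measured. It differs from compound 3 in one place: 1-methylazetidin-3-yl in place of 1-methyl-2-oxopiperidin-4-yl on an amide-type nitrogen. Within the data shown here, no measured step covers this exact change. The two steps that end at compound 3 show that the 1-methyl-2-oxopiperidin-4-yl gave modest gains over a methyl and over a (1-methyl-1H-pyrazol-4-yl)methyl, but they say nothing direct about a 1-methylazetidin-3-yl. With the ring changed and the carbonyl gone, compound 4 is expected to land close to compound 3, perhaps a little higher, so the expected step is a 1.7-fold higher number from compound 3 to compound 4 (0.23 log units; within the scatter). The estimate for compound 4 in this assay is 70 nM, with a range from 25 nM to 200 nM.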

Compound 4, half-maximal inhibitory concentration: 30 nM
Compound 4: the middle estimate sits 2.3-fold (0.37 log units) above what was measured; the measured number falls inside the stated range.
By their numbers in this assay, from the lowest: compounds 4 and 3 (each within the scatter of the next); then compounds 1 and 2 (each within the scatter of the next).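

In this assay, the 1-methylazetidin-3-yl on the amide-type nitrogen cannot be told apart from the 1-methyl-2-oxopiperidin-4-yl (a 1.4-fold lower number from compound 3 to compound 4 (0.14 log units; within the scatter)), so at this position, within these compounds, a smaller four-membered ring without a carbonyl holds the level that the earlier compounds had shown only for the six-membered ring. It also stands clear of both other groups on this nitrogen, the methyl (a 2.8-fold lower number from compound 1 to compound 4 (0.44 log units; beyond the scatter)) and the (1-methyl-1H-pyrazol-4-yl)methyl (a 5.3-fold lower number from compound 2 to compound 4 (0.72 log units; beyond the scatter)), which means that two different saturated rings, rather than one, now give lower numbers than those groups. No independent measurement accompanies these numbers to account for them.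

The compounds shown leave open what the two rings need in order to hold this level, since neither an azetidin-3-yl with hydrogen in place of the ring methyl nor a 1-methylpyrrolidin-3-yl, a five-membered ring of intermediate size, appears among them. Whether an open chain ending in an amine, such as a 2-(dimethylamino)ethyl, would serve this nitrogen equally well also remains unanswered.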